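The source may report more compounds than this note shows. Statements on the series, on what has been measured and on what is new or still open speak of the compounds shown alone.

Series notes. Compound 1 `CC(C)(C)CC(=O)Nc1cccc(C(=O)N2CCCC(C(=O)Nc3ccc(Cl)cc3)C2)c1` gives 0% in an ADME assay on PC-3 cells (Homo sapiens) for cytotoxicity, read by WST assay, tested at 100 uM (a higher number here means more inhibition at the concentration tested (going by the name of the read-out), a lower number less inhibition), and stands level with compound 2 `CC(=O)c1cccc(NC(=O)C2CCCN(C(=O)c3cc(C(F)(F)F)cc(C(F)(F)F)c3)C2)c1` at 0% and compound 3 `O=C(c1ccccc1)c1cccc(NC(=O)C2CCCN(C(=O)c3cc(C(F)(F)F)cc(C(F)(F)F)c3)C2)c1` at 0%. Among the compounds with values here, the one measured step, no change at the digits printed from compound 2 to compound 3 (within the scatter), alters a carbonyl carbon and leaves the read-out where it was. Compound 4 `CCN(CC)S(=O)(=O)c1cccc(C(=O)N2CCCC(C(=O)Nc3ccc(Cl)cc3)C2)c1` differs from compound 1 by diethylsulfamoyl in place of (neopentylcarbonyl)amino on an aromatic carbon. Within the data shown here, no measured step touches this position on the core of compound 1, so the data give no direct guide for this exchange; the only guide is that every measured compound sits at the same level. Compound 4 is therefore expected at 0%, range 0% to 12%. The step of no change at the digits printed from compound 1 to compound 4 (within the scatter) is expected to stay within the scatter.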

Compound 4, a percentage reported as inhibition, at one concentration (the size of the read-out at that concentration, not a potency): 0%
The estimate for compound 4 equals the measured number at the digits printed; the measured number falls inside the stated range.
By their numbers in this assay, from the lowest: compounds 1, 2, 3 and 4 (each within the scatter of the next).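

In this assay, within the data shown here, the exchange at this aromatic carbon gives no change at the digits printed from compound 1 to compound 4 (within the scatter) and is the first measured step at this position on the core of compound 1. Diethylsulfamoyl lacks the hydrogen-bond donor of (neopentylcarbonyl)amino and adds a sulfur atom, yet the read-out stays level. Nothing measured bears on why this result holds. Going by these compounds, whether an amine or a carboxylic acid on this aromatic carbon would shift the read-out remains open. So does whether any change at this position would separate a compound from the shared level.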